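The compounds below may be only part of what the source reports. "The series", "measured", "known", "first", "only" and "open" are said of these compounds alone.

The study turns on four compounds of one shared core, three of them already tested in an assay on isolated protein for inhibition of N-lysine methyltransferase SMYD2 (Homo sapiens), read by filter binding, with a stated time of 1 h; a lower number here means a stronger inhibitor, a higher number a weaker inhibitor. Compound 1 `C=CCC1COC2(C=CC(=O)C=C2)N(C(C)C)C1=O` reaches only a limit of the assay, > 20000 nM. Compound 2 `CC(C)N1C(=O)C(Cc2ccc(C(F)(F)F)cc2)COC12C=CC(=O)C=C2` likewise ends at a limit, > 20000 nM. Compound 3 `CN1C(=O)C(CCO)COC12C=CC(=O)C=C2` also stops at a limit, > 30000 nM. So compound 3 holds no number at all: it sits at the limit of > 30000 nM in this assay, at which 1 of the 3 values shown sits. The two others share (the limit of > 20000 nM in this assay, at which 2 of the 3 values shown sit). For the measured compounds named here, with nothing but limits, no measured step between any pair can be drawn, and no ordering among the three is possible.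

Compound 4 `CN1C(=O)C(CCNc2ccc(F)cc2)COC12C=CC(=O)C=C2` differs from compound 3 in one place: (4-fluorophenyl)amino in place of hydroxy on a saturated chain carbon, two bonds along the chain from a saturated ring carbon. Since the measured compounds give no numbers, the size or direction of this change cannot be read from them, and the account can only set an expectation. The step in this assay is expected to be an at least 1.5-fold lower number from compound 3 to compound 4 (0.17 log units; that floor lies within the scatter), which may amount to nothing beyond the scatter. For compound 4 the estimate in this assay is 20000 nM, expected within a range from 3000 nM to 100000 nM, and a further limit rather than a number remains the likelier outcome.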

Compound 4, half-maximal inhibitory concentration: 11600 nM
For compound 4 the middle estimate is 1.7-fold (0.24 log units) above the measured one, and the stated range covers the measured number.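

In this assay, for the compounds shown here, compound 4 gives 11600 nM, the first true number, so this saturated chain carbon, two bonds along the chain from a saturated ring carbon, can carry a group that brings a measurable reading. Placing (4-fluorophenyl)amino there in place of hydroxy gives an at least 2.5-fold lower number from compound 3 to compound 4 (0.41 log units; beyond the scatter), a change that lies beyond the scatter. That step is only a floor, and its true size stays unknown, as compound 3 holds a limit and not a number: the limit of > 30000 nM in this assay, at which 1 of the 4 values shown sits.

The compounds shown leave open whether a plain phenylamino group, a benzylamino group or a longer chain at this place would read the same, and how much of the step belongs to the fluorine. Also open is whether (4-fluorophenyl)amino would lift compound 1 or compound 2 off their limits: the limit of > 20000 nM in this assay, at which 2 of the 4 values shown sit.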